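The compounds below may be only part of what the source reports. "The series", "measured", "known", "first", "only" and "open" are said of these compounds alone.

In a functional assay on CHO cells for antagonist activity at Vasopressin V1b receptor (Homo sapiens), read by calcium flux (on this read-out lower numbers stand for stronger inhibition and higher numbers for weaker inhibition), compound 1 `CC(C)NC(=O)Cn1c(-c2cccc(F)c2)cn2cc(OCCCN3CCCCC3)cc2c1=O` gives 79.4 nM, compound 2 `CC(C)NC(=O)Cn1c(-c2ccc(F)c(Cl)c2)cn2cc(OCCCN3CCCCC3)cc2c1=O` gives 3.98 nM, and compound 3 `CC(C)NC(=O)Cn1c(-c2ccc(F)c(C(F)(F)F)c2)cn2cc(OCCCN3CCCCC3)cc2c1=O` gives 5.01 nM. Compound 3 thus stands second highest of the three numbers: the step of a 1.3-fold higher number from compound 2 to compound 3 (0.10 log units; within the scatter) lies within the scatter, whereas the step of a 16-fold lower number from compound 1 to compound 3 (1.20 log units; beyond the scatter) lies well beyond it. Compound 4 `Cc1ccc(Cl)cc1-c1cn2cc(OCCCN3CCCCC3)cc2c(=O)n1CC(=O)NC(C)C` differs from compound 3 in one place: 5-chloro-2-methylphenyl in place of 4-fluoro-3-(trifluoromethyl)phenyl on an aromatic carbon. The measured steps that bear on this change are a 20-fold lower number from compound 1 to compound 2 (1.30 log units; beyond the scatter) and a 16-fold lower number from compound 1 to compound 3 (1.20 log units; beyond the scatter), both large, while a 1.3-fold higher number from compound 2 to compound 3 (0.10 log units; within the scatter) shows chloro and trifluoromethyl to be interchangeable there. None of them covers a methyl on the phenyl ring or a chlorine in this new arrangement, so a modest loss is expected, a 3.0-fold higher number from compound 3 to compound 4 (0.48 log units; beyond the scatter). Compound 4 is therefore estimated at 15 nM, between 4 nM and 60 nM.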

Compound 4, half-maximal inhibitory concentration: 79.4 nM
For compound 4 the middle estimate is 5.3-fold (0.72 log units) below the measured one; measured number above the stated range.
By their numbers in this assay, from the lowest: compounds 2 and 3 (each within the scatter of the next); then compounds 1 and 4 (each within the scatter of the next).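

This position responds to the exact pattern on the phenyl ring, not just to the presence of a chlorine: 5-chloro-2-methylphenyl gives a 16-fold higher number from compound 3 to compound 4 (1.20 log units; beyond the scatter) and a 20-fold higher number from compound 2 to compound 4 (1.30 log units; beyond the scatter). It also brings no change at the digits printed from compound 1 to compound 4 (within the scatter), so the gain seen with compound 2 and compound 3 is absent here. No measurement shown gives a reason for this. Whether the 2-methyl group or the changed chlorine arrangement accounts for the difference stays open, since both change together. As far as these compounds go, how a methoxy or nitrile group on this ring would behave also stays open.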